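Series notes: triazole-linked lactones, step to compound 3

The source may report more compounds than this note shows. Statements on the series, on what has been measured and on what is new or still open speak of the compounds shown alone.

Compound 1 `O=C1O/C(=C\Cn2cc(-c3cc(F)cc(F)c3)nn2)C(OCc2ccccc2)=C1OCc1ccccc1` gives 17700 nM in a functional assay on HeLa cells (Homo sapiens) for antiproliferative activity, read by MTT assay, with a stated time of 72 h; on this read-out lower numbers stand for stronger inhibition and higher numbers for weaker inhibition. Compound 2 `COc1ccccc1-c1cn(C[C@H](O)[C@H]2OC(=O)C(OCc3ccccc3)=C2OCc2ccccc2)nn1` reaches only a limit of the measurement, > 100000 nM, which is the limit of this assay (the limit of > 100000 nM in this assay, at which 1 of the 2 values shown sits). Compound 3 `O=C1O[C@H]([C@@H](O)Cn2ccnn2)C(OCc2ccccc2)=C1OCc1ccccc1` differs from compound 2 by hydrogen in place of 2-methoxyphenyl on an aromatic carbon. With compound 2 giving no number, the step in this assay cannot be sized from measured pairs; the expected step from compound 2 to compound 3 is a step that the limit leaves unreadable from compound 2 to compound 3, with no direction claimed beyond the scatter. Compound 3 is estimated at 120000 nM, within 30000 nM to 400000 nM.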

Compound 3, half-maximal inhibitory concentration: > 100000 nM
Compound 3 gave a limit, no number; the forecaster's own chance of this, stated with the estimate: 60%; the middle value lies beyond the limit too.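

For the compounds shown here, compound 2 and compound 3 both stand at a limit of the measurement, so no step between them can be read: the limit of > 100000 nM in this assay, at which 2 of the 3 values shown sit. Going by these compounds, the size and direction of any effect of hydrogen in place of 2-methoxyphenyl on an aromatic carbon remain open.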